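A few compounds are considered here, and "the series" means these few. Any claim that something is new, unique, unknown or untested is made for them only; others in the source may bear on it.

Within the data shown here, in a functional assay on A549 cells (Homo sapiens) for antiproliferative activity, read by MTT assay, with a stated time of 48 h (a higher number here means a weaker inhibitor, a lower number a stronger inhibitor), two compounds have numbers so far: compound 1 (`Fc1ccc(-c2nn(-c3ccccc3)cc2-c2nc3cc(Br)ccc3[nH]2)cc1`) gives 5830 nM and compound 2 (`Fc1ccc2[nH]c(-c3cn(-c4ccccc4)nc3-c3ccc(Cl)cc3)nc2c1`) gives 4610 nM. These two values lie within the scatter of each other, so compound 2 cannot be separated from compound 1 on these numbers. Compound 3 (`Clc1ccc(-c2nn(-c3ccccc3)cc2-c2nc3cc(Br)ccc3[nH]2)cc1`) has not yet been measured. The change from compound 2 to compound 3 is bromo in place of fluoro on an aromatic carbon. Among the measured compounds shown here, the series offers no measured single-place step to serve as a guide. Compound 1 also carries a bromo group and gives 5830 nM, so in this assay a step no larger than the scatter is expected, with no favoured direction. The estimated change is a 1.1-fold higher number from compound 2 to compound 3 (0.04 log units; within the scatter). For compound 3 the expected value is 5000 nM, with an estimated range of 2500 nM to 10000 nM.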

Compound 3, half-maximal inhibitory concentration: 2170 nM
Beside the measured number, compound 3's estimate is 2.3-fold (0.36 log units) above it; measured number outside the range, below it.
By their numbers in this assay, from the lowest: compound 3; then compounds 2 and 1 (each within the scatter of the next).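

In this assay, bromo in place of fluoro on the fused ring gives a 2.1-fold lower number from compound 2 to compound 3 (0.33 log units; beyond the scatter), and chloro in place of fluoro on the other halogen-bearing aromatic carbon gives a 2.7-fold lower number from compound 1 to compound 3 (0.43 log units; beyond the scatter), so a change of halogen at either place moves the number beyond the scatter. Compound 3, which carries bromo and chloro together, is the strongest of the three, with both steps to it modest in size. Nothing measured here bears on why either step occurs.

Two single-place steps cannot show whether the halogen changes at the two places act independently, or whether the trend runs on beyond these halogens. Going by these compounds, the reading of a methoxy group, a nitrile or an amine at either place remains open, as does the effect of any group on the phenyl ring carried by the shared core.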